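Amide Substituent Swaps in a Cytotoxicity Series

The compounds below may be only part of what the source reports. "The series", "measured", "known", "first", "only" and "open" are said of these compounds alone.

Measured so far:
- compound 1, `C=CC1=C(C(=O)NCCC)C(c2ccc(F)cc2)OC1`: > 100000 nM
- compound 2, `C=CC1=C(C(=O)NCc2ccc(Cl)cc2)C(c2ccc(F)cc2)OC1`: 36900 nM

Of the compounds shown here, two sharing one core have been tested in a functional assay on QGY7701 cells (Homo sapiens) for cytotoxicity, read by MTT assay, with a stated time of 24 h; on this read-out higher numbers stand for weaker inhibition and lower numbers for stronger inhibition. For compound 1 the result is only a limit of the assay, namely (the limit of > 100000 nM in this assay, at which 1 of the 2 values shown sits). Among the compounds with values here, compound 2 is the only compound with an actual number in this assay, so it is the reference point for what follows. Within the data shown here, the one measured step, an at least 2.7-fold lower number from compound 1 to compound 2 (0.43 log units; beyond the scatter), shows that enlarging the group on the amide nitrogen from a short chain to a ring-bearing chain went along with a stronger effect.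

Compound 3 `C=CC1=C(C(=O)Nc2ccccc2OC)C(c2ccc(F)cc2)OC1` differs from compound 2 by 2-methoxyphenyl in place of 4-chlorobenzyl on an amide-type nitrogen. This keeps a six-membered aromatic ring on the amide nitrogen but removes the saturated carbon linking it, and exchanges the chlorine for a methoxy group. Among the measured compounds shown here, no measured step covers either of these changes, and the single measured step concerns a different part of the molecule, so it gives no direction for this one. The expectation is therefore a step of a 1.1-fold higher number from compound 2 to compound 3 (0.04 log units; within the scatter), that is, nothing beyond the scatter. Compound 3 is estimated at 40000 nM, with a range from 10000 nM to 150000 nM.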

Compound 3, half-maximal inhibitory concentration: 52800 nM
Estimate against measurement, compound 3: 1.3-fold (0.12 log units) below, within the range that was stated.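

In this assay, a 1.4-fold higher number from compound 2 to compound 3 (0.16 log units; within the scatter) means that 2-methoxyphenyl and 4-chlorobenzyl on the amide-type nitrogen cannot be told apart, so a ring set directly on that nitrogen, without a saturated linking carbon, gives a result that the scatter does not separate from the ring-bearing chain of compound 2. The comparison with the propyl group is less firm: an at least 1.8-fold lower number from compound 1 to compound 3 (0.27 log units; that floor lies within the scatter), so this floor alone does not separate compound 3 from compound 1, unlike the floor for compound 2. Compound 1 has no actual number, only a limit of the assay: the limit of > 100000 nM in this assay, at which 1 of the 3 values shown sits.

The step from 4-chlorobenzyl to 2-methoxyphenyl removes the linking carbon and exchanges chlorine for methoxy at once, and the compounds shown leave open what either change does alone. A 2-methoxybenzyl group or an unsubstituted phenyl on the same nitrogen would take these two changes apart, and a chain ending in an amine or a carboxylic acid would show whether an aromatic ring is needed there at all.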